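The source may hold more compounds than are shown below. What is called first, only, known or untested is meant among the compounds shown, and "the series" means these compounds.

Measured compounds in a functional assay on HepG2 cells (Homo sapiens) for antiproliferative activity, read by MTT assay, with a stated time of 24 h; a lower number here means a stronger inhibitor, a higher number a weaker inhibitor:
Compound 1 `COc1ccc(C(=O)/C=C/c2ccc(F)cc2)c2c1C=CC(C)(C)O2`: > 10000 nM (a limit)
Compound 2 `COc1ccc(C(=O)/C=C/c2cccc(F)c2)c2c1C=CC(C)(C)O2`: > 10000 nM (a limit)
Compound 3 `COc1ccc(/C=C/C(=O)c2ccc(OC)c3c2OC(C)(C)C=C3)cn1`: > 10000 nM (a limit)

On these numbers, compound 3 has no exact potency, only the limit > 10000 nM. It shares its position with the other two compounds, as the full set shows (the limit of > 10000 nM in this assay, at which 3 of the 3 values shown sit).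

Compound 4 `COc1ccc(C(=O)/C=C/c2cccs2)c2c1C=CC(C)(C)O2` carries thiophen-2-yl in place of 6-methoxypyridin-3-yl on a double-bonded chain carbon bound to a double-bonded chain carbon. The change is counted as follows: thiophen-2-yl in place of 6-methoxypyridin-3-yl on a double-bonded chain carbon bound to a double-bonded chain carbon.

Three measured steps involve changes at this same place: a step that the two limits leave unreadable from compound 1 to compound 2, a step that the two limits leave unreadable from compound 1 to compound 3 and a step that the two limits leave unreadable from compound 2 to compound 3. None of them has a readable size, so they supply no magnitude or direction to carry over to thiophen-2-yl. Neither the 4-fluorophenyl of compound 1, the 3-fluorophenyl of compound 2 nor the 6-methoxypyridin-3-yl of compound 3 gave a numerical value in this assay.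

The expected result is therefore a step that the limit leaves unreadable from compound 3 to compound 4, with no direction supported by the data. Another limit is the most likely report. For compound 4 the estimated value is 12000 nM. The expected range for compound 4 runs from 4000 nM to 30000 nM.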

Compound 4, half-maximal inhibitory concentration: > 10000 nM
Compound 4: only a limit was reported; the forecaster's own chance of this, stated with the estimate: 65%; the middle value lies beyond the limit too.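

In this assay compound 4 gives > 10000 nM, which is a limit, so its steps from compound 1, compound 2 and compound 3 cannot be read. All four compounds stand at the same place: the limit of > 10000 nM in this assay, at which 4 of the 4 values shown sit.

The compounds shown leave open whether thiophen-2-yl, 6-methoxypyridin-3-yl, 3-fluorophenyl and 4-fluorophenyl differ at all in potency.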